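A few compounds are considered here, and "the series" means these few. Any claim that something is new, unique, unknown or untested is made for them only; others in the source may bear on it.

Measured so far:
compound 1 `CC(C)n1nc(-c2cc(-c3ccccc3)on2)c(C(N)=O)c1N` — 236 nM
compound 2 `CC(C)n1nc(-c2cc(-c3ccccn3)on2)c(C(N)=O)c1N` — 4800 nM

In an assay on isolated protein for inhibition of proto-oncogene tyrosine-protein kinase receptor Ret (Homo sapiens), read by radiometric assay and 33P incorporation, in the presence of a further agent that is not named here (a lower number here means a stronger inhibitor, a higher number a weaker inhibitor), compound 1 gives the lowest of the two numbers measured, and its nearest neighbour is compound 2, separated by a 20-fold higher number from compound 1 to compound 2 (1.31 log units; beyond the scatter). That single step is the only one that bears on the present question, and it shows that exchanging the phenyl ring on this part of the shared core can carry a large cost.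

Compound 3 `CC(C)n1nc(-c2cc(-c3cccs3)on2)c(C(N)=O)c1N` is the next compound to be tested. It differs from compound 1 in one place: thiophen-2-yl in place of phenyl on an aromatic carbon. Among the compounds with values here, no measured pair shows this exact exchange, so the expectation rests on the one step from compound 1 to compound 2, which was large. Thiophen-2-yl is closer in size to phenyl than pyridin-2-yl, so a smaller change is expected in this assay, most likely a somewhat higher number, estimated as a 1.7-fold higher number from compound 1 to compound 3 (0.23 log units; within the scatter). Compound 3 is therefore expected to give about 400 nM, within a range from 130 nM to 1300 nM.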

Compound 3, half-maximal inhibitory concentration: 78 nM
Beside the measured number, compound 3's estimate is 5.1-fold (0.71 log units) above it; the measured number lies below the stated range.
By their numbers in this assay, from the lowest: compound 3; then compound 1; then compound 2.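

In this assay this position is not tied to phenyl: a 3.0-fold lower number from compound 1 to compound 3 (0.48 log units; beyond the scatter), so an exchange on this aromatic carbon next to the ring oxygen can lower the number as well as raise it. The ring that enters matters greatly, since a 62-fold lower number from compound 2 to compound 3 (1.79 log units; beyond the scatter), and simply having an aromatic ring at this place therefore does not settle the result. Nothing available explains why thiophen-2-yl and pyridin-2-yl differ so widely.

As far as these compounds go, it remains open whether the lower number belongs to thiophen-2-yl alone or would also appear with a close relative such as furan-2-yl or thiophen-3-yl. It is also unknown how a non-aromatic group at this place, such as cyclohexyl or a short ethyl chain, would compare with these rings.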